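Carbamate aryl fluorination and PANC-1 inhibition

This account rests on a few compounds, and the source may have more. Where it says the series, first, only, none or still open, it means among the compounds named here.

Compound 1, `CC(C)=CCC/C(C)=C/CC1Cc2c(OCC=C(C)C)cc(=O)n(CCCO)c2CC1(C)C`, gives 30.3% in a functional assay on PANC-1 cells (Homo sapiens) for inhibition, read by MTT assay, with a stated time of 24 h, tested at 10 uM; a higher number here means more inhibition at the concentration tested (going by the name of the read-out), a lower number less inhibition.
Compound 2, `CC(C)=CCC/C(C)=C/CC1Cc2c(OC(=O)Nc3ccc(F)cc3)cc(=O)n(CCCO)c2CC1(C)C`, gives 43.9% in this assay.
Compound 3, `CC(C)=CCC/C(C)=C/CC1Cc2c(OC(=O)Nc3ccccc3F)cc(=O)n(CCCO)c2CC1(C)C`, gives 71.6% in this assay.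

Compound 3 stands highest of the three numbers in this assay: compound 2 lies nearest, by a number 27.7 percentage points higher from compound 2 to compound 3 (beyond the scatter), and compound 1 furthest, by a number 41.3 percentage points higher from compound 1 to compound 3 (beyond the scatter), both gaps beyond the scatter. Compound 4, `CC(C)=CCC/C(C)=C/CC1Cc2c(OC(=O)Nc3ccc(F)c(F)c3)cc(=O)n(CCCO)c2CC1(C)C`, is not yet measured. It differs from compound 3 by 3,4-difluorophenyl in place of 2-fluorophenyl on an amide-type nitrogen.

Among the measured compounds shown here, only one measured step bears directly on this change: a number 27.7 percentage points higher from compound 2 to compound 3 (beyond the scatter), which shows that the (2-fluorophenyl)carbamoyl group stands well above the (4-fluorophenyl)carbamoyl group in this assay. Compound 4 keeps a fluorine in the 4-position of compound 2 and adds a second fluorine, but gives up the 2-fluorophenyl arrangement of compound 3. For the measured compounds named here, no measured pair shows the effect of a 3,4-difluorophenyl group. A downward step beyond the scatter is therefore expected, landing compound 4 between compound 2 and compound 3, an expected a number 21.6 percentage points lower from compound 3 to compound 4 (beyond the scatter). Compound 4 is estimated at 50%, within 32% to 68%.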

Compound 4, a percentage reported as inhibition, at one concentration (the size of the read-out at that concentration, not a potency): 43.7%
For compound 4 the middle estimate is 6.3 percentage points above the measured one, and the stated range covers the measured number.
By their numbers in this assay, from the lowest: compound 1; then compounds 4 and 2 (each within the scatter of the next); then compound 3.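

In this assay the added fluoro on the aromatic carbon changes nothing beyond the scatter, with a number 0.2 percentage points lower from compound 2 to compound 4 (within the scatter), so the 3,4-difluorophenyl group reads like the 4-fluorophenyl group and does not reach the 2-fluorophenyl group, as a number 27.9 percentage points lower from compound 3 to compound 4 (beyond the scatter) shows. The carbamate with this group still stands clear of the 3-methylbut-2-en-1-yl ether, with a number 13.4 percentage points higher from compound 1 to compound 4 (beyond the scatter), which leaves compound 3 alone at the top among the three carbamates. No evidence accounts for these differences.

The compounds shown leave open whether a 2,4-difluorophenyl group, which would keep the 2-fluoro of compound 3 and add the 4-fluoro of compound 2, would hold the high number of compound 3. They also leave open whether a 2-chlorophenyl or 2-methoxyphenyl group would do the same.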